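A Hexyl Chain Traded for a Methyl Ester

The compounds below may be only part of what the source reports. "The series", "measured", "known", "first", "only" and "open" are said of these compounds alone.

In a functional assay on KB cells (Homo sapiens) for inhibition (a higher number here means a weaker inhibitor, a lower number a stronger inhibitor), compound 1 `CCCCCCc1[nH]c2cc(OC)ccc2c1C(=O)c1cc(OC)c(OC)c(OC)c1` gives 37.8 nM, the lowest of the two numbers in hand. Compound 2 `COc1ccc2ccccc2c1-c1cc(C(=O)N/N=C/c2cccs2)[nH]n1` gives 5700 nM in this assay, a gap beyond the scatter. Compound 3 `COC(=O)c1[nH]c2cc(OC)ccc2c1C(=O)c1cc(OC)c(OC)c(OC)c1` is not yet measured; it differs from compound 1 by methoxycarbonyl in place of hexyl on an aromatic carbon, a methoxycarbonyl in place of hexyl on an aromatic carbon. Among the measured compounds shown here, no measured pair shows this change, so its size is open. Compound 3 is expected to come out weaker than compound 1, with a step of a 7.9-fold higher number from compound 1 to compound 3 (0.90 log units; beyond the scatter) in this assay. The estimate for compound 3 is 300 nM, within 60 nM to 2000 nM.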

Compound 3, half-maximal inhibitory concentration: 5.5 nM
Compound 3: middle estimate off by 55-fold (1.74 log units), on the high side; the measured number lies below the stated range.
By their numbers in this assay, from the lowest: compound 3; then compound 1; then compound 2.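

Methoxycarbonyl in place of hexyl on this aromatic carbon, next to the ring nitrogen, gives a 6.9-fold lower number from compound 1 to compound 3 (0.84 log units; beyond the scatter) in this assay, so the long hexyl chain is not required here for a low number. The entering group has fewer heavy atoms than hexyl and adds hydrogen-bond acceptors, but this single pair cannot separate those differences. No available evidence accounts for the step.

Going by these compounds, how a carboxylic acid, a primary amide or an ethyl group would compare on this carbon remains open. So does whether a chain between hexyl and methoxycarbonyl in size would follow the same direction.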